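From thiophen-3-yl to phenyl on the shared core

The source may hold more compounds than are shown below. What is called first, only, known or untested is meant among the compounds shown, and "the series" means these compounds.

Compound 1 `Nc1nc2c(c(-c3cccs3)cn2[C@@H]2O[C@H](CO)[C@@H](O)[C@H]2O)c(=O)[nH]1` and compound 2 `Nc1nc2c(c(-c3ccsc3)cn2[C@@H]2O[C@H](CO)[C@@H](O)[C@H]2O)c(=O)[nH]1` share one core and differ in the thiophene attachment. In a functional assay on HCT-116 cells (Homo sapiens), read by MTT assay, with a stated time of 72 h (a lower number here means a stronger inhibitor, a higher number a weaker inhibitor), compound 1 gives > 20000 nM, which is a limit and not a number. In this assay compound 2 gives > 20000 nM, also a limit. Among the measured compounds shown here, compound 2 therefore has no numeric standing, and the series so far stands at the limit of > 20000 nM in this assay, at which 2 of the 2 values shown sit.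

Compound 3 `Nc1nc2c(c(-c3ccccc3)cn2[C@@H]2O[C@H](CO)[C@@H](O)[C@H]2O)c(=O)[nH]1` carries phenyl in place of thiophen-3-yl on an aromatic carbon, two ring bonds from the ring nitrogen: phenyl in place of thiophen-3-yl on an aromatic carbon.

For the measured compounds named here, the only measured step that bears on this change is a step that the two limits leave unreadable from compound 1 to compound 2. It offers no size to carry forward, but it does show that moving the thiophene attachment leaves the reading at the limit. No step beyond the usual scatter is therefore expected in this assay, and no direction can be assigned. The estimated step is a number no higher from compound 2 to compound 3 (the limit leaves the size open). For compound 3 the expected value is 20000 nM, with an estimated range of 10000 nM to 40000 nM, and another report as a limit is the likeliest outcome.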

Compound 3, half-maximal inhibitory concentration: > 20000 nM
Compound 3: only a limit was reported; the forecaster's own chance of this, stated with the estimate: 85%; the middle value lies on the limit itself.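

In this assay compound 3 gives > 20000 nM, a limit and not a number. Among the compounds shown here, no step among compound 1, compound 2 and compound 3 can be read, and the series stands as follows: the limit of > 20000 nM in this assay, at which 3 of the 3 values shown sit. Still open, on these data alone, is whether thiophen-2-yl, thiophen-3-yl and phenyl differ at all on the shared core.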